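The source may report more compounds than this note shows. Statements on the series, on what has been measured and on what is new or still open speak of the compounds shown alone.

Compound 1 `CSc1nc(N)nc2c1ncn2/C=C1/CC1(CO)CO` gives > 100000 nM (a limit)
Compound 2 `Nc1nc(SC2CCCC2)c2ncn(/C=C3/CC3(CO)CO)c2n1` gives 91000 nM

In an ADME assay on CCRF-HSB-2 cells (Homo sapiens) for cytotoxicity, with a stated time of 7 days (on this read-out higher numbers stand for lower toxicity in this test and lower numbers for higher toxicity in this test), compound 1 gives > 100000 nM as a limit of the assay and not as a number. Among the compounds with values here, compound 2, at 91000 nM on the same read-out, holds the only actual number so far, so it cannot yet be ranked against a second number.

Compound 3 `CCCCCCOc1nc(N)nc2c1ncn2/C=C1/CC1(CO)CO` carries hexyloxy in place of cyclopentylsulfanyl on an aromatic carbon and so changes the group on the shared core. Within the data shown here, the one measured step is an at least 1.0-fold lower number from compound 1 to compound 2 (0.04 log units; that floor lies within the scatter) and it changes only the group on sulfur. Among the measured compounds shown here, it therefore offers a weak guide, since no measured step replaces that sulfur-linked group with an oxygen-linked chain. Also relevant is the limit of > 100000 nM in this assay, at which 1 of the 2 values shown sits, and so compound 3 may return only a limit.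

With so little to go on, a step no larger than the scatter is expected in this assay and no firm direction can be given. The expected change is a 1.3-fold lower number from compound 2 to compound 3 (0.11 log units; within the scatter) and it starts from compound 2 at 91000 nM as the anchor. Compound 3 is estimated at 70000 nM with an expected range from 25000 nM to 100000 nM for the measurement.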

Compound 3, half-maximal cytotoxic concentration: > 20000 nM
Compound 3 ended at the assay's limit (the forecaster's own chance of this, stated with the estimate: 30%); the middle value lies beyond the limit too.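

In this assay compound 3 gives > 20000 nM, which is a limit of the assay and not a number. Within the data shown here, no step from compound 1 or from compound 2 to compound 3 can be read. The compounds shown leave open whether hexyloxy, in place of methylsulfanyl or cyclopentylsulfanyl on an aromatic carbon, changes the toxicity in this test at all.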